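The source may report more compounds than this note shows. Statements on the series, on what has been measured and on what is new or still open speak of the compounds shown alone.

In an ADME assay on BJ cells (Homo sapiens) for cytotoxicity, with a stated time of 72 h (a lower number here means that less compound is needed, a higher number that more compound is needed for the effect), three compounds built on a shared core have been measured, and none of them has yet given a number. Compound 1 `Cc1cc(NC(=O)Nc2ccccc2N)c2ccccc2n1` reads > 25000 nM, which is a limit of the assay. Compound 2 `Cc1cc(NC(=O)Nc2ccc(F)c(F)c2)c2ccccc2n1` reads > 25000 nM, also a limit. Compound 3 `Cc1cc(NC(=O)Nc2ccc(F)cc2)c2ccccc2n1`, the starting point here, reads > 25000 nM, again a limit. The whole set therefore sits at the limit of > 25000 nM in this assay, at which 3 of the 3 values shown sit.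

Compound 4 `Cc1cc(NC(=O)Nc2ccc(OC(F)(F)F)cc2)c2ccccc2n1` carries trifluoromethoxy in place of fluoro on an aromatic carbon, para to a large group: trifluoromethoxy in place of fluoro on an aromatic carbon. For the measured compounds named here, two measured steps bear on this change, a step that the two limits leave unreadable from compound 1 to compound 3 and a step that the two limits leave unreadable from compound 2 to compound 3. Neither offers a size that could be carried over, so the forecast rests on where the three compounds stand rather than on any measured increment. Since all three share one limit, no step beyond the scatter is expected, and if compound 4 does give a number, it would be expected to fall on the lower side of the limit. The step expected here is an at least 1.1-fold lower number from compound 3 to compound 4 (0.05 log units; that floor lies within the scatter). Compound 4 will most likely report only a limit again. For compound 4 the estimate is 22000 nM, with an expected range from 9000 nM to 25000 nM.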

Compound 4, half-maximal effective concentration: 25000 nM
The estimate for compound 4 lay 1.1-fold (0.06 log units) below the measured number; the measured number falls inside the stated range.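

Replacing fluoro with trifluoromethoxy on an aromatic carbon, para to a large group, gives a number no higher from compound 3 to compound 4 (the limit leaves the size open). For the compounds shown here, this is the first time this position has yielded a readable value in this assay: compound 4 gives 25000 nM as a number. Even so, that number stands at the edge of what the other compounds leave open, and the size of the step stays unknown: the limit of > 25000 nM in this assay, at which 3 of the 4 values shown sit.

The other steps among these compounds cannot be read either, so the series still offers no measured increment for any change, and one number cannot show whether the trifluoromethoxy group shifts the read-out at all. On these data alone, it remains open whether a carboxylic acid, a nitrile or a longer alkoxy chain at this same place on the ring would give a number clearly lower than that of compound 4, and whether trifluoromethoxy would give a number at all on the ring carbons that carry other substituents in compound 1 and compound 2.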